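A few compounds are considered here, and "the series" means these few. Any claim that something is new, unique, unknown or untested is made for them only; others in the source may bear on it.

Measured so far in a functional assay on MDA-MB-231 cells (Homo sapiens), read by microscopy and transwell migration, with a stated time of 24 h; on this read-out higher numbers stand for weaker inhibition and lower numbers for stronger inhibition:
- Compound 1 `COc1ccccc1C(=O)Nc1nc(-c2cc(OC)c(OC)c(OC)c2)cs1`: 8500 nM
- Compound 2 `COc1ccc(C(=O)N(C)c2nc(-c3cc(OC)c(OC)c(OC)c3)cs2)cc1OC`: > 25000 nM (a limit, not a number)
- Compound 3 `COc1cc(C(=O)N(C)c2nc(-c3cc(OC)c(OC)c(OC)c3)cs2)cc(OC)c1OC`: 470 nM

Compound 2 is the only one of these without an exact number. It sits at the limit of > 25000 nM in this assay, at which 1 of the 3 values shown sits.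

The next compound to be measured is compound 4 `COc1ccccc1C(=O)N(C)c1nc(-c2cc(OC)c(OC)c(OC)c2)cs1`. It has 2-methoxyphenyl in place of 3,4-dimethoxyphenyl on a carbonyl carbon.

Going by the values given here, only one measured step bears on this same place. That step is an at least 53-fold lower number from compound 2 to compound 3 (1.72 log units; beyond the scatter), where methoxy replaces hydrogen on an aromatic carbon. Among the compounds with values here, it is a different change from the one in compound 4, but it shows that altering this group can move the number a long way in this assay.

Compound 1 also carries 2-methoxyphenyl on a carbonyl carbon, and compound 1 gives 8500 nM. This suggests that the group is compatible with a measurable number, although compound 1 differs from compound 4 elsewhere in the structure.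

The expected change is therefore an at least 6.2-fold lower number from compound 2 to compound 4 (0.79 log units; beyond the scatter), towards a lower number and stronger inhibition. Its true size remains uncertain, since the starting point is only a limit.

For compound 4, the estimated value is 4000 nM, with an expected range of 600 nM to 25000 nM.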

Compound 4, half-maximal inhibitory concentration: > 25000 nM
Compound 4 ended at the assay's limit; the forecaster's own chance of this, stated with the estimate: 20%; middle value at least 6.2-fold (0.79 log units) away from the limit.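

Going by these compounds alone, with 2-methoxyphenyl on the carbonyl carbon, methyl in place of hydrogen on the amide-type nitrogen gives an at least 2.9-fold higher number from compound 1 to compound 4 (0.46 log units; beyond the scatter), so in this assay this change weakens inhibition, which no earlier pair could show. Of the three compounds with methyl on that nitrogen, only compound 3 gives an exact number, 470 nM, so a single methoxy group in the 2-methoxyphenyl of compound 4 does not restore a measurable number in this series. Compound 2 and compound 4 now sit at the same limit, so the step between them, the swap of 3,4-dimethoxyphenyl for 2-methoxyphenyl, cannot be read: the limit of > 25000 nM in this assay, at which 2 of the 4 values shown sit.

Within the data shown here, it remains open whether methyl on the amide-type nitrogen has a similar effect with other groups on the carbonyl carbon, as the only readable comparison of this change involves 2-methoxyphenyl. Also open, on these data alone, is whether a longer chain such as ethyl on that nitrogen, or a carboxylic acid or an amine on the aromatic ring attached to the carbonyl carbon, would move the number in either direction.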